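The source may report more compounds than this note shows. Statements on the series, on what has been measured and on what is new or still open speak of the compounds shown alone.

Working notes on the series. The three measured compounds share one core and differ at two aryl groups. Compound 1 `O=C(CSc1nc(Nc2ccccc2)c2ccccc2n1)Nc1ccc(Cl)cc1` gives 12900 nM in a functional assay on PC-3 cells (Homo sapiens) for inhibition, read by MTT assay, with a stated time of 72 h; a lower number here means a stronger inhibitor, a higher number a weaker inhibitor. Compound 2 `O=C(CSc1nc(Nc2ccccc2)c2ccccc2n1)Nc1ccc([N+](=O)[O-])cc1` gives 25000 nM in this assay, and the step of a 1.9-fold higher number from compound 1 to compound 2 (0.29 log units; within the scatter) lies on the aryl amide end. Compound 3 `C=CC(=O)Nc1cccc(NC(=O)CSc2nc(Nc3ccccc3C)c3ccccc3n2)c1` gives 23200 nM in this assay; it stands second highest of the three numbers, with compound 2 nearest and compound 1 furthest, both gaps within the scatter, so no order among the three is claimed.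

Compound 4 `C=CC(=O)Nc1cccc(NC(=O)CSc2nc(Nc3ccc(F)c(Cl)c3)c3ccccc3n2)c1` has not yet been measured in this assay. It differs from compound 3 by 3-chloro-4-fluorophenyl in place of 2-methylphenyl on a nitrogen on an aromatic ring. Among the compounds with values here, no measured step touches this position: the only step recorded, a 1.9-fold higher number from compound 1 to compound 2 (0.29 log units; within the scatter), sits on the other aryl group, and all three numbers fall within the scatter of one another, so nothing in hand points in either direction for this exchange. The expectation is therefore a step that does not exceed the scatter, a 1.2-fold lower number from compound 3 to compound 4 (0.06 log units; within the scatter). Compound 4 is estimated at 20000 nM in this assay, with a range from 8000 nM to 50000 nM to cover the lack of any bearing step.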

Compound 4, half-maximal inhibitory concentration: > 50000 nM
Compound 4: only a limit was reported; the forecaster's own chance of this, stated with the estimate: 10%; at least 2.5-fold (0.39 log units) between middle value and limit.
By their numbers in this assay, from the lowest: compounds 1, 3 and 2 (each within the scatter of the next). At a limit, above all of these: compound 4.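

Within the data shown here, with 3-chloro-4-fluorophenyl in place of 2-methylphenyl on a nitrogen on an aromatic ring, the series shows an at least 2.1-fold higher number from compound 3 to compound 4 (0.33 log units; beyond the scatter), the first step in these notes beyond the scatter, whereas the only earlier step lay within it and on the aryl amide end. In this assay the reading for compound 4 is a limit and not a number, so this position is shown to matter for the read-out, but the full size of the step remains unknown. Compound 4 is alone at that limit among the compounds shown: the limit of > 50000 nM in this assay, at which 1 of the 4 values shown sits.

The exchange replaces the methyl group with two halogens at once, so these compounds do not separate the part played by the chlorine, the fluorine or the loss of the methyl group. Also open, going by these compounds, is whether a phenyl carrying chlorine alone or fluorine alone, or one carrying an amine or a carboxylic acid, on this same nitrogen would give a number close to that of compound 3 or another limit like that of compound 4.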